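A few compounds are considered here, and "the series" means these few. Any claim that something is new, unique, unknown or untested is made for them only; others in the source may bear on it.

Measured in a functional assay on K562 cells (Homo sapiens) for antiproliferative activity, with a stated time of 72 h; a lower number here means a stronger inhibitor, a higher number a weaker inhibitor:
- compound 1 `Nc1ncnn2c([C@@H]3O[C@H](CO)[C@@H](O)[C@H]3O)cc(-c3ccc(F)cc3)c12`: > 100000 nM
- compound 2 `COc1ccc(-c2cc([C@@H]3O[C@H](CO)[C@@H](O)[C@H]3O)n3ncnc(N)c23)cc1`: 76400 nM

The reading for compound 1 is a limit. Going by the values given here, compound 2 therefore holds the only actual number. Compound 3 `Nc1ncnn2c([C@@H]3O[C@H](CO)[C@@H](O)[C@H]3O)cc(-c3ccsc3)c12` carries thiophen-3-yl in place of 4-methoxyphenyl on an aromatic carbon. Among the compounds with values here, the sole measured step, an at least 1.3-fold lower number from compound 1 to compound 2 (0.11 log units; that floor lies within the scatter), swaps a group on the phenyl ring and offers only weak guidance for replacing the ring itself. Compound 2 stands at 76400 nM. Little room remains before the limit of this assay, so a measurable change is expected to be toward a lower number. The expected change is a 3.1-fold lower number from compound 2 to compound 3 (0.49 log units; beyond the scatter), with low confidence. Compound 3 is estimated at 25000 nM, within a range of 2000 nM to 100000 nM.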

Compound 3, half-maximal inhibitory concentration: 66400 nM
The estimate for compound 3 lay 2.7-fold (0.42 log units) below the measured number; low and high end bracket the measured number.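

Exchanging the whole aromatic ring at this position, rather than a group on it, gives no separable change in this assay: a 1.2-fold lower number from compound 2 to compound 3 (0.06 log units; within the scatter). The ring swap from 4-fluorophenyl gives only a floor, an at least 1.5-fold lower number from compound 1 to compound 3 (0.17 log units; that floor lies within the scatter). Compound 1 stands at a limit, not a number: the limit of > 100000 nM in this assay, at which 1 of the 3 values shown sits.

So at this position, neither ring size nor the exchange of a carbon-only ring for a sulfur-bearing one separates the values shown. Open, on these data alone, is whether an amine or a longer alkyl chain here would give a number clearly apart from these.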